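Aminomethyl to 1-amino-1-methylethyl on a carbonyl carbon

The source may report more compounds than this note shows. Statements on the series, on what has been measured and on what is new or still open speak of the compounds shown alone.

Of the compounds shown here, three with closely related cores have been tested in a functional assay on U-87MG ATCC cells (Homo sapiens) for antiproliferative activity; a lower number here means a stronger inhibitor, a higher number a weaker inhibitor. Compound 1 `Cc1c2c(n3c1CCN(C(=O)CN)C[C@@H](C)[C@H](C)Nc1cc-3ccc1C(N)=O)CC(C)(C)CC2=O` gives 378 nM, the highest number of the three and beyond the scatter from both others. Compound 2 `Cc1c2c(n3c1CCCN(C(=O)CO)[C@@H](C)[C@H](C)Nc1cc-3ccc1C(N)=O)CC(C)(C)CC2=O` gives 111 nM, and compound 3 `COCCC(=O)N1CCCc2c(C)c3c(n2-c2ccc(C(N)=O)c(c2)N[C@@H](C)[C@@H]1C)CC(C)(C)CC3=O` gives 80 nM.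

Compound 4 `Cc1c2c(n3c1CCN(C(=O)C(C)(C)N)C[C@@H](C)[C@H](C)Nc1cc-3ccc1C(N)=O)CC(C)(C)CC2=O` keeps the core of compound 1 and alters one group: 1-amino-1-methylethyl in place of aminomethyl on a carbonyl carbon. Going by the values given here, no measured pair makes this exact change. Among the compounds with values here, the only measured step that bears on it is a 1.4-fold lower number from compound 2 to compound 3 (0.14 log units; within the scatter), which puts methoxymethyl in place of hydroxy on a saturated chain carbon bound to a carbonyl carbon. That step lies within the scatter, but it is a single step, on a different core and with different groups, so it offers only weak guidance. A change beyond the scatter is therefore not expected, and the estimated step is a 1.3-fold lower number from compound 1 to compound 4 (0.10 log units; within the scatter). Compound 4 is expected at 300 nM, with an estimated range of 110 nM to 800 nM.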

Compound 4, half-maximal inhibitory concentration: 39 nM
The estimate for compound 4 lay 7.7-fold (0.89 log units) above the measured number; measured number outside the range, below it.
By their numbers in this assay, from the lowest: compound 4; then compounds 3 and 2 (each within the scatter of the next); then compound 1.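

On the core of compound 1, 1-amino-1-methylethyl in place of aminomethyl on a carbonyl carbon gives a 9.7-fold lower number from compound 1 to compound 4 (0.99 log units; beyond the scatter) in this assay, although the counts of hydrogen-bond donors and acceptors stay the same. Going by these compounds alone, the only earlier step, a 1.4-fold lower number from compound 2 to compound 3 (0.14 log units; within the scatter), lay within the scatter and on a different core, so compound 4 gives the first evidence here that a change in this group can move the number beyond the scatter. Nothing measured here gives a reason for this step.

Going by these compounds, it remains open whether 1-aminoethyl would give part of this drop, or whether 1-hydroxy-1-methylethyl would show that the amine is needed. On these data alone, it also remains open whether 1-amino-1-methylethyl would have a similar effect on the cores of compound 2 and compound 3.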